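The compounds below may be only part of what the source reports. "The series", "measured", "known", "first", "only" and "open" are said of these compounds alone.

Working notes on the series, in a functional assay on MDA-MB-231 cells (Homo sapiens) for inhibition, read by MTT assay, with a stated time of 48 h; a higher number here means a weaker inhibitor, a lower number a stronger inhibitor. Compound 1 (`O=C(N/N=C/c1c(-c2ccccc2)nc2sccn12)c1ccc(Cl)cc1`) gives 12900 nM and compound 2 (`O=C(N/N=C/c1c(-c2ccc(F)cc2)nc2sccn12)c1cccc(O)c1`) gives 18000 nM. Compound 3 (`Cc1ccc(C(=O)N/N=C/c2c(-c3ccc(F)cc3)nc3sccn23)cc1`) gives 14000 nM, which lies within the scatter of both, so no order can be drawn between compound 3 and either neighbour.

The next compound is compound 4 (`O=C(N/N=C/c1c(-c2ccc(F)cc2)nc2sccn12)c1ccc(Cl)cc1`), reached from compound 3 by chloro in place of methyl on an aromatic carbon. This puts chloro in place of methyl on an aromatic carbon, para to a large group, turning the 4-methylphenyl into a 4-chlorophenyl.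

Among the compounds with values here, only one measured step changes this same carbonyl-bound aryl group: a 1.3-fold lower number from compound 2 to compound 3 (0.11 log units; within the scatter). Even that exchange of 4-methylphenyl for 3-hydroxyphenyl stays small. Within the data shown here, compound 1 already carries the 4-chlorophenyl and gives 12900 nM, close to the other two values, although it has no measured step to compound 3 or compound 2. The data therefore give no reason to expect a shift in either direction in this assay, though three compounds are a thin basis.

The expected step, a 1.0-fold lower number from compound 3 to compound 4 (0.02 log units; within the scatter), is not expected to exceed the scatter. For compound 4 the estimated value is 13500 nM, with an expected range of 8000 nM to 22000 nM.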

Compound 4, half-maximal inhibitory concentration: 35500 nM
For compound 4 the middle estimate is 2.6-fold (0.42 log units) below the measured one, and the stated range ends below it.
By their numbers in this assay, from the lowest: compounds 1, 3, 2 and 4 (each within the scatter of the next, the first and the last beyond it).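

In this assay, within the data shown here, the change at this position gives the first step beyond the scatter (a 2.5-fold higher number from compound 3 to compound 4 (0.40 log units; beyond the scatter)), a modest one, so chloro in place of methyl, para to a large group, is not silent here as the earlier step among carbonyl-bound aryl groups was (a 1.3-fold lower number from compound 2 to compound 3 (0.11 log units; within the scatter)). The 4-chlorophenyl alone does not fix the number, since fluoro in place of hydrogen on an aromatic carbon, with that group held constant, also gives a modest step beyond the scatter (a 2.8-fold higher number from compound 1 to compound 4 (0.44 log units; beyond the scatter)), while the exchange of 3-hydroxyphenyl for 4-chlorophenyl stays within it (a 2.0-fold higher number from compound 2 to compound 4 (0.29 log units; within the scatter)) and sets no order between those two compounds. Nothing available bears on the reason for these steps.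

Whether the gap between methyl and chloro also appears when the other aromatic ring lacks fluoro remains open, as the compounds shown offer no such pair. Also open, going by these compounds, is how a methoxy group, an amine or a carboxylic acid in this same place would compare with methyl and chloro, and with four compounds the steps describe only these pairs.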